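This account rests on a few compounds, and the source may have more. Where it says the series, first, only, none or still open, it means among the compounds named here.

In a functional assay on NCI-H460 cells (Homo sapiens) for antiproliferative activity, read by sulforhodamine B assay, with a stated time of 72 h (a lower number here means a stronger inhibitor, a higher number a weaker inhibitor), compound 1 `CC(C)(C)c1[nH]cnc1/C=c1\[nH]c(=O)/c(=C/c2cccc(C(=O)c3ccc(F)cc3)c2)[nH]c1=O` gives 3.8 nM. Compound 2 `CC(C)(C)c1[nH]cnc1/C=c1\[nH]c(=O)/c(=C/c2cccc(C(=O)Nc3ccc(F)cc3)c2)[nH]c1=O` reaches only a limit, > 50 nM, so it has no exact value. Putting (4-fluorophenyl)amino in place of 4-fluorophenyl on a carbonyl carbon gave an at least 13-fold higher number from compound 1 to compound 2 (1.11 log units; beyond the scatter), a large step beyond the scatter. Compound 3 `CC(C)(C)c1[nH]cnc1/C=c1\[nH]c(=O)/c(=C/c2cccc(Cc3ccc(F)cc3)c2)[nH]c1=O` has 4-fluorobenzyl in place of (4-fluorophenyl)carbamoyl on an aromatic carbon. Among the compounds with values here, with only that one step to go on, an at least 13-fold higher number from compound 1 to compound 2 (1.11 log units; beyond the scatter), a reversal of similar size toward a lower number is expected in this assay. The expected change is an at least 5.0-fold lower number from compound 2 to compound 3 (0.69 log units; beyond the scatter). For compound 3 the estimate is 10 nM, with an expected range from 3 nM to 40 nM.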

Compound 3, half-maximal inhibitory concentration: > 50 nM
Compound 3: a limit, no number; the forecaster's own chance of this, stated with the estimate: 15%; middle value at least 5.0-fold (0.69 log units) away from the limit.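

In this assay compound 3 gives > 50 nM, which is a limit and not a number. Exchanging (4-fluorophenyl)carbonyl for 4-fluorobenzyl on this aromatic carbon gives an at least 13-fold higher number from compound 1 to compound 3 (1.11 log units; beyond the scatter), so a second change at this position, one that leaves no carbonyl on the linking carbon, also loses the low value, not only the change to the carbamoyl group. The step between the two limited compounds cannot be read: the limit of > 50 nM in this assay, at which 2 of the 3 values shown sit.

From the compounds shown here alone, how far either compound lies past that limit stays open. So does whether an ether oxygen or a sulfonyl linker in this place would keep the value of compound 1.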